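Replacing methoxy with hydrogen on compound 2

A few compounds are considered here, and "the series" means these few. Any claim that something is new, unique, unknown or untested is made for them only; others in the source may bear on it.

In a functional assay on U-251 cells (Homo sapiens) for inhibition, read by sulforhodamine B assay, with a stated time of 48 h, tested at 10 uM (on this read-out lower numbers stand for less inhibition of growth and higher numbers for more inhibition of growth at the one concentration tested), compound 2 (`COc1ccc(-c2nc3sc(-c4ccccc4)cn3n2)cc1`) gives 21% and stands highest of the three compounds measured. Compound 1 (`CC(=O)c1ccc(NC(=O)Cn2nc(-c3ccc(Cl)cc3)nc2N)cc1`) gives 5.94% in this assay and so lies below it by more than the scatter, while compound 3 (`COc1ccc(-c2nc3sc(-c4ccc(Cl)cc4)cn3n2)cc1`) gives -67.9% and lies lowest.

The change to compound 4 (`c1ccc(-c2nc3sc(-c4ccccc4)cn3n2)cc1`) is hydrogen in place of methoxy on an aromatic carbon and the rest of the structure stays the same. For the measured compounds named here, only one measured step bears on this, and only indirectly. Chloro in place of hydrogen on an aromatic carbon gives a number 88.9 percentage points lower from compound 2 to compound 3 (beyond the scatter) and this large step lies beyond the scatter. It concerns a different group at a different place, so it shows that one small substitution can move the read-out strongly in this series, yet it gives no size for the loss of methoxy. Going by the values given here, no measured pair removes that group. A small downward step is therefore expected, perhaps none beyond the scatter, though with a wide margin on either side. The expected change is a number 7 percentage points lower from compound 2 to compound 4 (within the scatter) on this estimate. Compound 4 is estimated at 14% within an expected range from -30% to 45% in this assay when it is measured.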

Compound 4, percent growth inhibition at one concentration: 6%
For compound 4 the middle estimate is 8 percentage points above the measured one, within the range that was stated.
By their numbers in this assay, from the lowest: compound 3; then compounds 1 and 4 (each within the scatter of the next); then compound 2.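

For the compounds shown here, compound 4 gives the first direct reading of this position: in this assay, hydrogen in place of methoxy on an aromatic carbon, para to a large group, gives a number 15 percentage points lower from compound 2 to compound 4 (beyond the scatter). Going by these compounds alone, the position therefore registers the change, and the methoxy-bearing compound 2 holds the higher number of this pair, a result the earlier compounds could not show because none of them removed that group. This modest step still differs in size from the large one elsewhere on the structure, a number 88.9 percentage points lower from compound 2 to compound 3 (beyond the scatter), so in these two single changes from compound 2 the number falls both times, but by clearly different amounts. No measurement at hand explains why the loss of methoxy lowers the number.

The compounds shown leave open whether an amine, a hydroxyl or a longer alkoxy chain in the same place would give a number nearer to that of compound 2 or to that of compound 4. They also leave open whether chloro would bring as large a step on the core of compound 4, which lacks methoxy, as it does on compound 2.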